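Swapping a Phenyl Ring for a Pyrimidine

The compounds below may be only part of what the source reports. "The series", "measured", "known", "first", "only" and "open" are said of these compounds alone.

In an ADME assay on microsomes from liver (Homo sapiens) for metabolic stability (a lower number here means slower removal, a higher number faster removal of the compound), compound 3 `Cn1ncc(-c2nn(C)c3ncnc(N4CCC4)c23)c1-c1ccc(C2CC2)cc1` gives 90 mL/min/kg, a higher number than compound 1 `CCc1ccc(-c2c(-c3nn(C)c4ncnc(N5CC(NC(=O)OC)C5)c34)cnn2C)cc1` at 42 mL/min/kg. Compound 2 `Cc1ccc(-c2c(-c3nn(C)c4ncnc(N5CCC5)c34)cnn2C)cc1` gives 47 mL/min/kg. Among the compounds with values here, the only measured step, a 1.9-fold higher number from compound 2 to compound 3 (0.28 log units; within the scatter), puts cyclopropyl in place of methyl on an aromatic carbon and replaces no ring, so it offers little guidance here. Compound 4 `Cn1ncc(-c2nn(C)c3ncnc(N4CCC4)c23)c1-c1ncc(C2CC2)cn1` carries 5-cyclopropylpyrimidin-2-yl in place of 4-cyclopropylphenyl (5-cyclopropylpyrimidin-2-yl in place of 4-cyclopropylphenyl on an aromatic carbon), and with it hydrogen-bond acceptors enter. With no measured ring swap to draw on, the expectation rests on this structural change alone. The estimated step in this assay is a 2.6-fold lower number from compound 3 to compound 4 (0.41 log units; beyond the scatter), towards a lower number. For compound 4 the expected value is 35 mL/min/kg, with an estimated range from 15 mL/min/kg to 70 mL/min/kg.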

Compound 4, clearance: 28 mL/min/kg
Estimate against measurement, compound 4: 1.3-fold (0.10 log units) above; measured number inside the range.
By their numbers in this assay, from the lowest: compounds 4, 1, 2 and 3 (each within the scatter of the next, the first and the last beyond it).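

In this assay, within the data shown here, the step of a 3.2-fold lower number from compound 3 to compound 4 (0.51 log units; beyond the scatter) is the first ring swap seen at this position, and it lies beyond the scatter even though the cyclopropyl group stays in place. Measured against the 4-methylphenyl compound, the same pyrimidine gives a 1.7-fold lower number from compound 2 to compound 4 (0.22 log units; within the scatter) and stays within the scatter, so the change stands out only in the pair that keeps cyclopropyl. Nothing shown explains why the number moves. Still open, on these data alone, is how a pyridine ring, holding a single ring nitrogen, or 5-methylpyrimidin-2-yl would compare with compound 4 at this position.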